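The source may report more compounds than this note shows. Statements on the series, on what has been measured and on what is new or still open speak of the compounds shown alone.

Measured compounds in a functional assay on CCRF-CEM cells (Homo sapiens) for cytotoxicity, read by MTT assay, with a stated time of 72 h; on this read-out lower numbers stand for stronger inhibition of growth and higher numbers for weaker inhibition of growth:
Compound 1, `CCCCC[Se]c1nc(NCc2ccc(SC)cc2)c2ccccc2n1`, gives 83900 nM.
Compound 2, `CSc1ccc(CNc2nc([SeH])nc3ccccc23)cc1`, gives only a limit of the assay, > 100000 nM.
Compound 3, `Nc1nc([SeH])nc2ncccc12`, gives 61500 nM.

Compound 2 and compound 1 differ in one place: pentyl in place of hydrogen on a selenium. The step this made, an at least 1.1-fold lower number from compound 2 to compound 1 (0.07 log units; that floor lies within the scatter), is read against (the limit of > 100000 nM in this assay, at which 1 of the 3 values shown sits), so only a floor for its size is known. The difference between the cores of compound 3 and compound 2 is not broken down here. Compound 4, `CCCCC[Se]c1nc(N)c2cccnc2n1`, is reached from compound 3 by the same change: pentyl in place of hydrogen on a selenium. The place is identical in both pairs, a selenium whose other neighbours are aromatic carbon, so this is the same change rather than merely the same kind. For the measured compounds named here, the expectation for compound 4 in this assay rests on the one measured instance, an at least 1.1-fold lower number from compound 2 to compound 1 (0.07 log units; that floor lies within the scatter), whose floor lies within scatter and sets no firm size. Compound 4 is expected to show a step of a 1.5-fold lower number from compound 3 to compound 4 (0.19 log units; within the scatter), modest and possibly within scatter. Compound 4 is estimated at 40000 nM, between 15000 nM and 100000 nM.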

Compound 4, concentration for total growth inhibition: 42800 nM
Estimate against measurement, compound 4: 1.1-fold (0.03 log units) below, and the stated range covers the measured number.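

Pentyl in place of hydrogen on a selenium now has a second reading in this assay: the new step, a 1.4-fold lower number from compound 3 to compound 4 (0.16 log units; within the scatter), stays as small as the scatter allows a reader to say, so it shows no firm effect of the change on the core of compound 3. Set beside the earlier step, the two cores give no sign of a difference, but they give no proof of agreement either: the same change on two cores in this assay, an at least 1.1-fold lower number (0.07 log units; that floor lies within the scatter) from compound 2 to compound 1 and a 1.4-fold lower number (0.16 log units; within the scatter) from compound 3 to compound 4; the limit leaves it open whether they differ. Going by these compounds, the carry-over from one core to the other therefore remains untested in size, since the earlier step has only a floor, and the two readings show only that nothing beyond the scatter has been seen so far: the limit of > 100000 nM in this assay, at which 1 of the 4 values shown sits.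

Still open, on these data alone, is whether a longer chain such as octyl, a shorter one such as ethyl, or a benzyl group on the selenium would give a step beyond the scatter on either core. Also open, as far as these compounds go, is whether pentyl would behave alike on a third core, where both the hydrogen form and the pentyl form gave numbers clear of the limit.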